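A Smaller Amide Substituent Tested Against Cholesterol Transporter Binding

This account rests on a few compounds, and the source may have more. Where it says the series, first, only, none or still open, it means among the compounds named here.

Compound 3 `CC(C)(C)c1ccc(C(=O)N2CCC3(CC2)C(=O)N(CC(=O)N2CCN(S(C)(=O)=O)CC2)CN3c2ccccc2)cc1` gives the higher of the two numbers recorded in an assay on HEK293 cells for displacement of a labelled ligand from NPC1-like intracellular cholesterol transporter 1 (Homo sapiens); a higher number here means a weaker inhibitor, a lower number a stronger inhibitor: compound 3 gives 19000 nM, while compound 2 `CC(C)(C)c1ccc(C(=O)N2CCC3(CC2)C(=O)N(CC(=O)NCCO)CN3c2ccccc2)cc1` gives 1000 nM. Compound 1 `CC(C)(C)OC(=O)NCCCCNC(=O)CN1CN(c2ccccc2)C2(CCN(C(=O)c3ccc(C(C)(C)C)cc3)CC2)C1=O` is recorded as "not determined" (no result reported) in this assay. Among the compounds with values here, the single measured step, a 19-fold higher number from compound 2 to compound 3 (1.28 log units; beyond the scatter), shows that swapping the hydroxyethylamino group for the sulfonylpiperazine on the carbonyl carbon weakened binding markedly. Compound 4 `CC(C)(C)c1ccc(C(=O)N2CCC3(CC2)C(=O)N(CC(=O)NCN)CN3c2ccccc2)cc1` moves back toward a small, donor-bearing group: (aminomethyl)amino in place of 4-(methylsulfonyl)piperazin-1-yl on a carbonyl carbon. This bears on the measured step in the opposite direction, so a gain in binding is expected. For compound 4 the expected step is a 13-fold lower number from compound 3 to compound 4 (1.10 log units; beyond the scatter) because of the loss seen in a 19-fold higher number from compound 2 to compound 3 (1.28 log units; beyond the scatter). Compound 4 is therefore estimated at 1500 nM, with a range from 400 nM to 8000 nM.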

Compound 4, half-maximal inhibitory concentration: 26500 nM
Compound 4: middle estimate off by 18-fold (1.25 log units), on the low side, outside the stated range (above it).
By their numbers in this assay, from the lowest: compound 2; then compounds 3 and 4 (each within the scatter of the next).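

In this assay, a small group carrying hydrogen-bond donors does not by itself bring binding back: (aminomethyl)amino in place of 4-(methylsulfonyl)piperazin-1-yl on a carbonyl carbon gives a 1.4-fold higher number from compound 3 to compound 4 (0.14 log units; within the scatter). A much smaller exchange also proves decisive, as amino in place of hydroxymethyl on a saturated chain carbon bound to an amide-type nitrogen gives a 27-fold higher number from compound 2 to compound 4 (1.42 log units; beyond the scatter). No measurement available here explains this loss. Still open, going by these compounds, is whether a methoxy group in place of the hydroxyl, or a longer chain ending in a hydroxyl, would keep the binding of compound 2.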